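Ester chain length on two cores, adenosine A2b binding

The source may hold more compounds than are shown below. What is called first, only, known or untested is meant among the compounds shown, and "the series" means these compounds.

Compound 1 `COC(=O)C1=C(C)NC(=S)NC1c1ccsc1` and compound 2 `CCCOC(=O)C1=C(C)NC(=S)NC1c1ccsc1` share one core and differ only in the ester chain; compound 3 `COC(=O)C1=C(C)N(C)C(=O)NC1c1ccoc1` and compound 4 `CCCOC(=O)C1=C(C)N(C)C(=O)NC1c1ccoc1` share another. The difference between the two cores is not broken down here. In an assay on membranes from HEK293 cells for displacement of a labelled ligand from adenosine receptor A2b (Homo sapiens), read by scintillation counting, with a stated time of 30 min, tested at 1 uM (on this read-out higher numbers stand for more inhibition at the one concentration tested (going by the name of the read-out) and lower numbers for less inhibition), compound 1 gives 38%, and compound 2 gives 26%. The step of a number 12 percentage points lower from compound 1 to compound 2 (beyond the scatter) goes with the change (ethyl in place of hydrogen on a saturated chain carbon bound to an oxygen next to a carbonyl group). Compound 3 gives 7% in this assay, the lowest of the three measured values. Compound 4 carries the same change, (ethyl in place of hydrogen on a saturated chain carbon bound to an oxygen next to a carbonyl group), at a place described in the same words, so this is the same change on a different core. Compound 4 is not yet measured in this assay. Going by the values given here, because compound 3 starts from 7% and the only measured precedent is the step of a number 12 percentage points lower from compound 1 to compound 2 (beyond the scatter), a further fall is expected but the read-out leaves little room below, so compound 4 is expected to show a step of about a number 5 percentage points lower from compound 3 to compound 4 (within the scatter). Compound 4 is therefore estimated at 2%, with a likely range from -10% to 14%.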

Compound 4, a percentage reported as inhibition, at one concentration (the size of the read-out at that concentration, not a potency): 2%
Compound 4: middle estimate and measured number agree at the digits printed; the measured number falls inside the stated range.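

Going from methoxycarbonyl to propoxycarbonyl on the second core in this assay gives a number 5 percentage points lower from compound 3 to compound 4 (within the scatter), and this step can be set beside the earlier one: the same change on two cores in this assay, a number 12 percentage points lower (beyond the scatter) from compound 1 to compound 2 and a number 5 percentage points lower (within the scatter) from compound 3 to compound 4, 7 percentage points apart, within the scatter of two such steps. The two steps therefore cannot be told apart, and the data are compatible with the change carrying over from the core of compound 1 to the core of compound 3, although the step on the core of compound 3 does not establish a fall on its own. Two pairs do not show that the change behaves alike on other cores, and single-concentration percentages near the bottom of the read-out say nothing about potency.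

Still open, from the compounds shown here alone, is whether an ethoxycarbonyl group, a longer chain such as butoxycarbonyl, or a carboxylic acid at this place would follow the same direction on either core. Also open, going by these compounds, is which of the several differences between the two cores matters, as compound 1 and compound 3 differ in more than one place.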